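Ethyl in Place of Methoxy on the Sulfonamide Aryl Group

The source may hold more compounds than are shown below. What is called first, only, known or untested is meant among the compounds shown, and "the series" means these compounds.

Measured so far in a functional assay on HT-29 cells (Homo sapiens) for antiproliferative activity, read by sulforhodamine B assay, with a stated time of 48 h; a lower number here means a stronger inhibitor, a higher number a weaker inhibitor:
compound 1, `CCc1ccccc1NS(=O)(=O)c1ccc(N2CCNC2=O)cc1`: 240 nM
compound 2, `O=C1NCCN1c1ccc(S(=O)(=O)Nc2cccc(Br)c2)cc1`: 77 nM
compound 3, `COc1ccc(NS(=O)(=O)c2ccc(N3CCNC3=O)cc2)cc1`: 800 nM

All three share one core and differ only in the aryl group on the sulfonamide nitrogen. Compound 3 has the highest number of the three: the steps of a 3.3-fold higher number from compound 1 to compound 3 (0.52 log units; beyond the scatter) and a 10-fold higher number from compound 2 to compound 3 (1.02 log units; beyond the scatter) both run upward, and the step of a 3.1-fold lower number from compound 1 to compound 2 (0.49 log units; beyond the scatter) shows that the 3-bromophenyl compound sits lowest.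

Compound 4, `CCc1ccc(NS(=O)(=O)c2ccc(N3CCNC3=O)cc2)cc1`, differs from compound 3 by ethyl in place of methoxy on an aromatic carbon. For the measured compounds named here, no measured pair swaps these two groups at the same position. The nearest guide is a 3.3-fold higher number from compound 1 to compound 3 (0.52 log units; beyond the scatter), which changes both the group and where it sits, so it bears on compound 4 only loosely. Compound 4 is expected to move part of the way back toward compound 1, with a 2.0-fold lower number from compound 3 to compound 4 (0.30 log units; within the scatter) as a modest downward step. For compound 4 the estimate in this assay is 400 nM, with a range from 150 nM to 1200 nM.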

Compound 4, half-maximal inhibitory concentration: 660 nM
Beside the measured number, compound 4's estimate is 1.7-fold (0.22 log units) below it; low and high end bracket the measured number.
By their numbers in this assay, from the lowest: compound 2; then compound 1; then compounds 4 and 3 (each within the scatter of the next).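

In this assay the swap of methoxy for ethyl on an aromatic carbon para to a large group takes away a hydrogen-bond acceptor, yet the two numbers stay within the usual scatter (a 1.2-fold lower number from compound 3 to compound 4 (0.08 log units; within the scatter)). The position of the ethyl group does count, since 4-ethylphenyl in place of 2-ethylphenyl gives a step beyond the scatter (a 2.8-fold higher number from compound 1 to compound 4 (0.44 log units; beyond the scatter)), and 4-ethylphenyl in place of 3-bromophenyl gives a larger one (an 8.6-fold higher number from compound 2 to compound 4 (0.93 log units; beyond the scatter)). Nothing available explains these differences.

On these data alone, whether the low number of compound 2 belongs to the bromine or to where it sits remains open, and a 3-ethylphenyl or 4-bromophenyl group would separate the two. An amine, a carboxylic acid or a longer chain such as propyl at this position also remains untested among the compounds shown.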